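Taking the amino group off compound 1

The compounds below may be only part of what the source reports. "The series", "measured", "known", "first", "only" and "open" are said of these compounds alone.

Going by the values given here, in a functional assay on MGC-803 cells (Homo sapiens) for inhibition, read by MTT assay, with a stated time of 48 h (on this read-out higher numbers stand for weaker inhibition and lower numbers for stronger inhibition), compound 1 (`C/C=C/C(=O)N(Cc1ccc(OC)c(N)c1)c1cc(OC)c(OC)c(OC)c1`) gives 150 nM as the only actual number so far. Compound 2 (`COc1cc(NCc2ccc(Br)cc2)cc(OC)c1OC`) shows > 80000 nM in this test, which is a limit and not a number. Compound 1 therefore has no measured neighbour to be ranked against. Compound 3 (`C/C=C/C(=O)N(Cc1ccc(OC)cc1)c1cc(OC)c(OC)c(OC)c1`) departs from compound 1 in one place (hydrogen in place of amino on an aromatic carbon): hydrogen in place of amino on an aromatic carbon, so that 3-amino-4-methoxyphenyl becomes 4-methoxyphenyl. Among the compounds with values here, no measured step covers this change, and the expectation starts from compound 1 at 150 nM alone. In this assay a moderate loss of inhibition, beyond the scatter, seems likely. The estimated change is a 5.3-fold higher number from compound 1 to compound 3 (0.73 log units; beyond the scatter) towards a higher number. Compound 3 is expected at 800 nM with an estimated range from 200 nM to 5000 nM for the measurement.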

Compound 3, half-maximal inhibitory concentration: 450 nM
For compound 3 the middle estimate is 1.8-fold (0.25 log units) above the measured one, and the stated range covers the measured number.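

In this assay the amino group on this aromatic carbon, ortho to a methoxy group, makes a real but modest contribution, with removal giving a 3.0-fold higher number from compound 1 to compound 3 (0.48 log units; beyond the scatter). It is not indispensable, since compound 3, which carries hydrogen at this position, still gives 450 nM in this assay. Nothing shown here bears on why the change has this size.

The compounds shown leave open whether the amino group itself matters or whether another group at this position, such as a hydroxyl group, a fluorine atom or a methylamino group, would serve as well. They also leave open whether moving the amino group to another carbon of the ring, or replacing the 4-methoxy group with an ethoxy group, would change the reading.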